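Ehrlich Cell Cytotoxicity of Three Aryl Analogues

The source may report more compounds than this note shows. Statements on the series, on what has been measured and on what is new or still open speak of the compounds shown alone.

Compound 1 `COc1cc(N2C(N)=C(C#N)C(c3cccs3)C3=C2CC(C)(C)CC3=O)cc(OC)c1OC`: 10%
Compound 2 `COc1cc(N2C(N)=C(C#N)C(c3ccc(O)cc3)C3=C2CC(C)(C)CC3=O)cc(OC)c1OC`: 20%
Compound 3 `COc1cc(N2C(N)=C(C#N)C(c3ccc(C)cc3)C3=C2CC(C)(C)CC3=O)cc(OC)c1OC`: 50%

All three compounds were tested in a functional assay on Ehrlich cells (Mus musculus) for cytotoxicity, tested at 25 ug/mL; on this read-out lower numbers stand for a weaker effect and higher numbers for a stronger effect at the one concentration tested. Compound 3 stands highest of the three numbers; compound 2 is its nearest neighbour, and compound 1 lies furthest from it.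

Compound 4 `COc1cc(N2C(N)=C(C#N)C(c3c(OC)ccc4ccccc34)C3=C2CC(C)(C)CC3=O)cc(OC)c1OC` differs from compound 3 in one place: 2-methoxynaphthalen-1-yl in place of 4-methylphenyl on a saturated ring carbon.

Among the compounds with values here, the steps that bear on this change are those that swap the group on the same saturated ring carbon. The step of a number 40 percentage points higher from compound 1 to compound 3 (beyond the scatter) was large, and the step of a number 10 percentage points higher from compound 1 to compound 2 (within the scatter) stayed within the scatter, while a number 30 percentage points higher from compound 2 to compound 3 (beyond the scatter) was modest. Together these show that changing the aryl group at this carbon can shift the read-out in this assay by a large amount, but none of them involves a two-ring aryl group or a methoxy group, so the direction for compound 4 is uncertain.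

For compound 4 the number is therefore estimated at 40%, with a range from 15% to 65%, which means an expected step of a number 10 percentage points lower from compound 3 to compound 4 (within the scatter), a small drop that may well fall within the scatter.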

Compound 4, a percentage reported as activity, at one concentration (the size of the read-out at that concentration, not a potency): 5%
Beside the measured number, compound 4's estimate is 35 percentage points above it; the measured number lies below the stated range.
By their numbers in this assay, from the lowest: compounds 4, 1 and 2 (each within the scatter of the next, the first and the last beyond it); then compound 3.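

In this assay, the change at this saturated ring carbon gives a number 45 percentage points lower from compound 3 to compound 4 (beyond the scatter), so a larger group with two aromatic rings and one hydrogen-bond acceptor does not keep the read-out seen with 4-methylphenyl. The new group can also be placed against the two other groups: the change gives a number 15 percentage points lower from compound 2 to compound 4 (beyond the scatter) against 4-hydroxyphenyl, and a number 5 percentage points lower from compound 1 to compound 4 (within the scatter) against thiophen-2-yl, so among these four compounds only 4-methylphenyl stands clear of every other group at this carbon. Nothing measured on these compounds accounts for the size of this drop.

The compounds shown leave open whether the lower number goes with the second aromatic ring or with the methoxy group, as both enter together in compound 4. They also leave open how the read-out would respond to a plain naphthalen-1-yl group at this carbon, or to a phenyl ring carrying an amine or a carboxylic acid, either of which would test this position further.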